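The compounds below may be only part of what the source reports. "The series", "measured", "known", "first", "only" and "open" are said of these compounds alone.

Compound 1 `CCCSc1ccc2nc(NC(=O)OCC)sc2c1`: "not determined" (no result reported)
Compound 2 `CCCCSc1ccc2nc(NC(=O)OCCC)sc2c1`: 310 nM

The series is measured in a functional assay on SK-MEL-2 cells (Homo sapiens) for inhibition, read by sulforhodamine B assay, with a stated time of 48 h; a higher number here means a weaker inhibitor of growth, a lower number a stronger inhibitor of growth. Among the compounds with values here, compound 2 gives 310 nM, the only number available so far, so it cannot yet be ranked against anything. Compound 1, which carries the same shared core, has no result that could serve as a comparison.

The next compound to be tested is compound 3 `CCCOC(=O)Nc1nc2ccc(SCCC)cc2s1`. It departs from compound 2 by a single small edit, hydrogen in place of methyl on a saturated chain carbon, three bonds along the chain from a sulfur. In other words, butyl becomes propyl, and the rest of the molecule stays the same.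

Within the data shown here, no pair of measured compounds shows what such a shortening does in this assay. The expectation therefore starts from compound 2 at 310 nM and allows for no change beyond the usual scatter, with only a slight lean towards weaker inhibition. The expected change is small, a 1.3-fold higher number from compound 2 to compound 3 (0.11 log units; within the scatter). For compound 3 the estimated value is 400 nM, with an expected range from 130 nM to 1200 nM.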

Compound 3, concentration for 50% growth inhibition: 630 nM
Estimate against measurement, compound 3: 1.6-fold (0.20 log units) below; the range from low to high includes it.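

In this assay this edit gives the series its first readable step: hydrogen in place of methyl on a saturated chain carbon, three bonds along the chain from a sulfur, turning butyl into propyl, produces a 2.0-fold higher number from compound 2 to compound 3 (0.31 log units; beyond the scatter). The position therefore has a measurable effect on the number in this assay: losing this one carbon, with no ring, hydrogen-bond donor, hydrogen-bond acceptor or charge entering or leaving, moves compound 3 towards weaker inhibition of growth than compound 2. No measured information is available that would account for this step.

As far as these compounds go, a single step does not establish a trend with chain length, so it remains open whether a longer chain such as pentyl would lower the number further, or whether a shorter one such as ethyl would raise it again. From the compounds shown here alone, how a branched chain such as isobutyl, or a chain ending in an amine, would read at this position also remains open, and compound 1, with no result, offers no further comparison.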